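The source may report more compounds than this note shows. Statements on the series, on what has been measured and on what is new or still open speak of the compounds shown alone.

Compound 1 `CC(C)(C)Sc1c(CC(C)(C)C(=O)O)n(Cc2ccc(Cl)cc2)c2ccc(OCc3nc4ccccc4s3)cc12` gives 260 nM in a functional assay (blood) for inhibition, with Homo sapiens as the target; on this read-out higher numbers stand for weaker inhibition and lower numbers for stronger inhibition. Compound 2 `COc1ccc2nc(COc3ccc4c(c3)c(SC(C)(C)C)c(CC(C)(C)C(=O)O)n4Cc3ccc(Cl)cc3)sc2c1` gives 670 nM. Compound 3 `CC(C)(C)Sc1c(CC(C)(C)C(=O)O)n(Cc2ccc(Cl)cc2)c2ccc(OCc3ccncc3)cc12` gives > 3000 nM, which is a limit of the assay and not a number.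

Compound 3 thus stands at the weak end of the three, at the limit (the limit of > 3000 nM in this assay, at which 1 of the 3 values shown sits). Compound 4 `CC(C)c1csc(COc2ccc3c(c2)c(SC(C)(C)C)c(CC(C)(C)C(=O)O)n3Cc2ccc(Cl)cc2)n1` differs from it by 4-isopropyl-1,3-thiazol-2-yl in place of pyridin-4-yl on a saturated chain carbon bound to an oxygen on an aromatic ring. Going by the values given here, two measured steps bear on this position: an at least 11-fold higher number from compound 1 to compound 3 (1.06 log units; beyond the scatter) and an at least 4.4-fold higher number from compound 2 to compound 3 (0.65 log units; beyond the scatter), both losses when pyridin-4-yl entered in place of a 1,3-benzothiazol-2-yl group. Since 4-isopropyl-1,3-thiazol-2-yl shares the thiazole part of that group, a partial recovery is expected for compound 4. For compound 4 the expected step is an at least 3.3-fold lower number from compound 3 to compound 4 (0.52 log units; beyond the scatter). Compound 4 is therefore estimated at 900 nM, between 300 nM and 3000 nM.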

Compound 4, half-maximal inhibitory concentration: > 3000 nM
Compound 4: a limit, no number; the forecaster's own chance of this, stated with the estimate: 25%; at least 3.3-fold (0.52 log units) between middle value and limit.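

In this assay compound 4 gives > 3000 nM, which is a limit of the assay and not a number. A second group now falls short of the benzothiazoles: 4-isopropyl-1,3-thiazol-2-yl in place of 1,3-benzothiazol-2-yl gives an at least 11-fold higher number from compound 1 to compound 4 (1.06 log units; beyond the scatter), and in place of 6-methoxy-1,3-benzothiazol-2-yl it gives an at least 4.4-fold higher number from compound 2 to compound 4 (0.65 log units; beyond the scatter). The step between the pyridin-4-yl and 4-isopropyl-1,3-thiazol-2-yl compounds cannot be read, so these two groups cannot be ranked: the limit of > 3000 nM in this assay, at which 2 of the 4 values shown sit.

Still open, from the compounds shown here alone, is how a plain 1,3-thiazol-2-yl or a quinolin-2-yl group would read on this saturated chain carbon.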